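This account rests on a few compounds, and the source may have more. Where it says the series, first, only, none or still open, it means among the compounds named here.

Compound 1, `CC1(C)CC(=O)C(C(=S)SCCO)=C(Nc2ccc(Cl)cc2Cl)C1`, and compound 2, `CCCCSC(=S)C1=C(Nc2ccc(Br)cc2)CC(C)(C)CC1=O`, have both been tested in a functional assay on PBMC cells (Homo sapiens) for inhibition, read by ELISA, with a stated time of 18 h; on this read-out higher numbers stand for weaker inhibition and lower numbers for stronger inhibition. In this assay compound 1 gives > 20 ug/mL, which is a limit of the assay rather than a number. Compound 2 likewise gives > 20 ug/mL, again only a limit. Compound 2 thus stands at the limit of > 20 ug/mL in this assay, at which 2 of the 2 values shown sit. Compound 3, `CC1(C)CC(=O)C(C(=S)SCCO)=C(Nc2ccc(Br)cc2)C1`, is not yet measured; it differs from compound 2 by hydroxy in place of ethyl on a saturated chain carbon, two bonds along the chain from a sulfur. Since compound 2 rests at the limit of > 20 ug/mL in this assay, at which 2 of the 2 values shown sit, no step beyond the scatter is expected in this assay, and the estimated step is a step that the limit leaves unreadable from compound 2 to compound 3. Compound 3 is expected to give about 30 ug/mL, within 10 ug/mL to 100 ug/mL, most likely again reported as a limit.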

Compound 3, half-maximal inhibitory concentration: > 20 ug/mL
Compound 3: a limit, no number; the forecaster's own chance of this, stated with the estimate: 80%; the middle value lies beyond the limit too.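

In this assay, among the compounds shown here, compound 3 gives > 20 ug/mL, again a limit and not a number, so no step to compound 3 can be read from compound 1 or compound 2. What the compounds shown leave open is how their true values compare: the limit of > 20 ug/mL in this assay, at which 3 of the 3 values shown sit.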